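Ethyl in Place of Chloro on a Thioether Benzamide

The compounds below may be only part of what the source reports. "The series", "measured", "known", "first", "only" and "open" are said of these compounds alone.

Compound 1, `Nc1ccccc1NC(=O)c1ccc(CSc2ccc(Br)cc2)cc1`, gives 4.35% in a functional assay on A-375 cells (Homo sapiens) for inhibition, read by CCK-8 assay, with a stated time of 72 h, tested at 2 uM; a lower number here means less inhibition of growth, a higher number more inhibition of growth at the concentration tested.
Compound 2, `Nc1ccccc1NC(=O)/C=C/c1ccc(CSc2ccc(Cl)cc2)cc1`, gives 13.4% in this assay.
Compound 3, `Nc1ccccc1NC(=O)c1ccc(CSc2ccc(Cl)cc2)cc1`, gives 25.3% in this assay.

Compound 2 stands second highest of these three numbers: compound 1 lies lower within the scatter, compound 3 higher beyond it. Compound 4, `CCc1ccc(SCc2ccc(/C=C/C(=O)Nc3ccccc3N)cc2)cc1`, differs from compound 2 by ethyl in place of chloro on an aromatic carbon. Among the compounds with values here, the only measured step, a number 21 percentage points higher from compound 1 to compound 3 (beyond the scatter), swaps one halogen for another in a different core and so offers no guide to an ethyl group. Within the data shown here, with no step bearing on this change, no shift beyond the scatter is expected. Compound 4 is therefore estimated at 13%, within 2% to 30%, a step of a number 0.4 percentage points lower from compound 2 to compound 4 (within the scatter) expected from compound 2.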

Compound 4, percent growth inhibition at one concentration: 5.27%
Compound 4: the middle estimate sits 7.7 percentage points above what was measured; measured number inside the range.
By their numbers in this assay, from the lowest: compounds 1, 4 and 2 (each within the scatter of the next); then compound 3.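

In this assay, ethyl in place of chloro gives a number 8.1 percentage points lower from compound 2 to compound 4 (within the scatter) and so cannot be told apart from no change. Within the data shown here, this is the first step at this position that replaces a halogen with a carbon group, and it shows that 4-ethylphenyl can stand where 4-chlorophenyl stood without a clear shift in growth inhibition. No measurement shown here explains this result.

On these data alone, whether an amine, a methoxy group or a longer chain at this position would move the number beyond the scatter remains open. So does whether ethyl would behave the same way on the core of compound 3.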